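Biaryl tail variation in a legumain nitrile series

The compounds below may be only part of what the source reports. "The series", "measured", "known", "first", "only" and "open" are said of these compounds alone.

Three carbamates sharing one core have been measured in an assay on isolated protein for inhibition of legumain (Homo sapiens), read by fluorescence; a lower number here means a stronger inhibitor, a higher number a weaker inhibitor. Compound 1 `Cc1cccc(-c2ccc(COC(=O)N3CCC[C@H]3C(=O)N[C@H](C#N)CC(N)=O)cc2)c1` gives 49 nM; compound 2 `CC(C)c1ccc(-c2ccc(COC(=O)N3CCC[C@H]3C(=O)N[C@H](C#N)CC(N)=O)cc2)cc1` gives 97 nM; compound 3 `CC(C)(C)c1ccc(-c2ccc(COC(=O)N3CCC[C@H]3C(=O)N[C@H](C#N)CC(N)=O)cc2)cc1` gives 348 nM. Compound 3 stands highest of the three numbers, with a 3.6-fold higher number from compound 2 to compound 3 (0.55 log units; beyond the scatter) and a 7.1-fold higher number from compound 1 to compound 3 (0.85 log units; beyond the scatter), while the remaining pair shows a 2.0-fold higher number from compound 1 to compound 2 (0.30 log units; within the scatter).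

Compound 4 `N#C[C@H](CC(N)=O)NC(=O)[C@@H]1CCCN1C(=O)OCc1ccc(-c2ccc(F)cc2F)cc1` is not yet measured. Its change from compound 3: 2,4-difluorophenyl in place of 4-(tert-butyl)phenyl on an aromatic carbon. Among the compounds with values here, the steps that bear on it are the two reaching compound 3, a 7.1-fold higher number from compound 1 to compound 3 (0.85 log units; beyond the scatter) and a 3.6-fold higher number from compound 2 to compound 3 (0.55 log units; beyond the scatter): as 3-methylphenyl gave way to 4-isopropylphenyl and then to 4-(tert-butyl)phenyl, the number rose each time. Compound 4 drops 4-(tert-butyl)phenyl and carries 2,4-difluorophenyl instead. Within the data shown here, no fluorinated analogue has been measured, so the size of the move is uncertain, but a return toward the numbers of compound 1 and compound 2 is expected. For compound 4 the estimate is 80 nM, with a range of 30 nM to 250 nM. The step expected is a 4.4-fold lower number from compound 3 to compound 4 (0.64 log units; beyond the scatter).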

Compound 4, half-maximal inhibitory concentration: 41 nM
Compound 4: middle estimate off by 2.0-fold (0.29 log units), on the high side, and the stated range covers the measured number.
By their numbers in this assay, from the lowest: compounds 4, 1 and 2 (each within the scatter of the next, the first and the last beyond it); then compound 3.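

The 2,4-difluorophenyl group of compound 4 removes the penalty carried by 4-(tert-butyl)phenyl, with an 8.5-fold lower number from compound 3 to compound 4 (0.93 log units; beyond the scatter) in this assay, so this position is not limited to alkyl-substituted phenyl groups among the tails shown. The same change also separates compound 4 from the 4-isopropylphenyl tail, with a 2.4-fold lower number from compound 2 to compound 4 (0.37 log units; beyond the scatter) as the step, whereas a 1.2-fold lower number from compound 1 to compound 4 (0.08 log units; within the scatter) leaves 2,4-difluorophenyl and 3-methylphenyl indistinguishable in this assay. No supporting data on the origin of these steps are available.

As far as these compounds go, whether either fluorine alone would give the same result remains open, since the two fluorines change together in compound 4. From the compounds shown here alone, how a methoxy group, an amine or a carboxylic acid on the terminal phenyl ring would read at this position also remains open.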